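The source may hold more compounds than are shown below. What is called first, only, known or untested is meant among the compounds shown, and "the series" means these compounds.

- Compound 1 `COc1cc(C(=O)c2cn(-c3ccccc3N)cc2-c2ccccc2)cc(OC)c1OC` gives 3800 nM
- Compound 2 `COc1cc(C(=O)c2cn(-c3cccc([N+](=O)[O-])c3)cc2-c2ccccc2)cc(OC)c1OC` gives 550 nM
- Compound 3 `COc1cc(C(=O)c2cn(-c3ccccc3)cc2-c2ccccc2Cl)cc(OC)c1OC` gives 76 nM

In a functional assay on MCF7 cells (Homo sapiens) for cytotoxicity, read by MTT assay, with a stated time of 96 h (a lower number here means a stronger inhibitor, a higher number a weaker inhibitor), compound 3 has the lowest number of the three (76 nM), making it the strongest inhibitor so far. Compound 4 `COc1cc(C(=O)c2cn(-c3ccccc3)cc2-c2ccc([N+](=O)[O-])cc2)cc(OC)c1OC` carries 4-nitrophenyl in place of 2-chlorophenyl on an aromatic carbon. Going by the values given here, no measured step touches this place. The nearest is a 6.9-fold lower number from compound 1 to compound 2 (0.84 log units; beyond the scatter), a modest change made on an aromatic nitrogen instead, so it offers only a rough size. Among the compounds with values here, compound 2, the only measured compound with a nitrophenyl group, sits at 550 nM in this assay, which points towards a higher number. The expected change is modest, a 3.9-fold higher number from compound 3 to compound 4 (0.60 log units; beyond the scatter), though this is uncertain. Compound 4 is estimated at 300 nM (70 nM to 1300 nM).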

Compound 4, half-maximal inhibitory concentration: 590 nM
Beside the measured number, compound 4's estimate is 2.0-fold (0.29 log units) below it, and the stated range covers the measured number.
By their numbers in this assay, from the lowest: compound 3; then compounds 2 and 4 (each within the scatter of the next); then compound 1.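

In this assay, this change on the aromatic carbon of the five-membered ring gives a 7.8-fold higher number from compound 3 to compound 4 (0.89 log units; beyond the scatter) and so shows that the number responds to the group held at this position. The step swaps chlorine for nitro and also moves that group around the phenyl ring, so it cannot show which of the two matters. Nothing available here explains the rise.

As far as these compounds go, what a 4-chlorophenyl or a 2-nitrophenyl would give at this position remains open. Either group would help separate the identity of the group from its location on the phenyl ring.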